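The source may report more compounds than this note shows. Statements on the series, on what has been measured and on what is new or still open speak of the compounds shown alone.

Measured in a physicochemical assay for lipophilicity, measured as octanol-water partition, at pH 7.4; a lower number here means a more polar compound, a higher number a more lipophilic compound:
compound 1 `CC(C)c1noc(N2CCC(Oc3cc(N4CCc5cc(N6CCCCC6=O)ccc54)ncn3)CC2)n1`: 3.8
compound 2 `CC(=O)N(C)c1ccc2c(c1)CCN2c1cc(OC2CCN(c3nc(C(C)C)no3)CC2)ncn1`: 3.7

Going by the values given here, compound 2 is not separated from the only other measured compound, and the single measured step is a number 0.10 log units lower from compound 1 to compound 2 (within the scatter). Compound 3 `CC(C)c1noc(N2CCC(Oc3cc(N4CCc5cc(N6CCOCC6=O)ccc54)ncn3)CC2)n1` has not yet been measured. It carries 3-oxomorpholin-4-yl in place of the acetyl(methyl)amino of compound 2, on an aromatic carbon: 3-oxomorpholin-4-yl in place of acetyl(methyl)amino on an aromatic carbon.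

The measured step bears on this change only in part. It exchanged 2-oxopiperidin-1-yl for acetyl(methyl)amino on an aromatic carbon, and neither group is a ring with 2 hetero atoms. Among the compounds with values here, no measured compound carries the entering group, so the series offers no direct precedent for it. Resting on the structural change alone, a moderate move towards a lower number is expected in this assay, with less confidence than a measured precedent would give. The expected size is a number 0.40 log units lower from compound 2 to compound 3 (beyond the scatter). The starting point for this expectation is compound 2 at 3.7. For compound 3 the estimated value is 3.3, with an expected range of 2.9 to 3.6.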

Compound 3, distribution coefficient: 3.1
Estimate against measurement, compound 3: 0.20 log units above; low and high end bracket the measured number.
By their numbers in this assay, from the lowest: compound 3; then compounds 2 and 1 (each within the scatter of the next).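

In this assay, going by these compounds alone, the position on the aromatic carbon now separates compounds, whereas the only earlier exchange there stayed within the scatter. Entry of 3-oxomorpholin-4-yl gives a number 0.60 log units lower from compound 2 to compound 3 (beyond the scatter) and also a number 0.70 log units lower from compound 1 to compound 3 (beyond the scatter) against the closest ring analogue, so the change stands out from both acetyl(methyl)amino and 2-oxopiperidin-1-yl, which themselves remain unseparated. The second comparison keeps a six-membered non-aromatic ring with its carbonyl in place and shows that the open-chain or ring form of the amide is not needed to obtain a step of this kind, though nothing among the data accounts for the size of the step.

The three compounds leave open whether the step follows the ring oxygen specifically, since a ring carrying a second nitrogen, such as an oxopiperazine, or an open chain carrying an ether oxygen would separate the ring from that atom. Also open, on these data alone, is how far the number would move with an amine or a carboxylic acid on the same aromatic carbon, and whether the step holds on a different core.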